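Lengthening the hydroxy-bearing chain of compound 2

A few compounds are considered here, and "the series" means these few. Any claim that something is new, unique, unknown or untested is made for them only; others in the source may bear on it.

Values in a functional assay on HCT-116 cells (Homo sapiens) for antiproliferative activity; a higher number here means a weaker inhibitor, a lower number a stronger inhibitor:
Compound 1 `C=CCO/N=C/c1c(N)ncnc1Oc1ccc2[nH]c(C)cc2c1F`: 40 nM
Compound 2 `Cc1cc2c(F)c(Oc3ncnc(N)c3/C=N/OCCO)ccc2[nH]1`: 323 nM
Compound 3 `CO/N=C/c1c(N)ncnc1Oc1cc2cc[nH]c2cc1F`: 422 nM

Compound 2 lies within the usual scatter of compound 3, so the two cannot be ranked against each other. Both carry higher numbers than compound 1. Within the data shown here, the gap to compound 1 is the only step measured between compounds that differ in one place, and it is an 8.1-fold higher number from compound 1 to compound 2 (0.91 log units; beyond the scatter).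

Compound 4 `Cc1cc2c(F)c(Oc3ncnc(N)c3/C=N/OCCCO)ccc2[nH]1` departs from compound 2 by hydroxymethyl in place of hydroxy on a saturated chain carbon, two bonds along the chain from an oxygen. This is hydroxymethyl in place of hydroxy on a saturated chain carbon, two bonds along the chain from an oxygen, so 2-hydroxyethoxy becomes 3-hydroxypropoxy.

Among the measured compounds shown here, no measured step shows this change directly, so the evidence is indirect. The step from compound 1 swaps vinyl for hydroxymethyl, and compound 4 still carries the hydroxy group that compound 1 lacks. A step as large as an 8.1-fold higher number from compound 1 to compound 2 (0.91 log units; beyond the scatter) is therefore not expected here, and the data offer only a weak hint of direction. In this assay the expected change is small, estimated as a 1.4-fold lower number from compound 2 to compound 4 (0.15 log units; within the scatter).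

The estimate for compound 4 is 230 nM, with an expected range from 100 nM to 600 nM.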

Compound 4, half-maximal inhibitory concentration: 452 nM
Compound 4: the middle estimate sits 2.0-fold (0.29 log units) below what was measured; the measured number falls inside the stated range.
By their numbers in this assay, from the lowest: compound 1; then compounds 2, 3 and 4 (each within the scatter of the next).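

In this assay, the step from 2-hydroxyethoxy to 3-hydroxypropoxy is a 1.4-fold higher number from compound 2 to compound 4 (0.15 log units; within the scatter), so at this position the two hydroxy-bearing chains cannot be told apart. The difference from the vinyl-bearing chain of compound 1, already seen with compound 2, also holds for the longer chain, at an 11-fold higher number from compound 1 to compound 4 (1.05 log units; beyond the scatter), and among the compounds shown, both hydroxy-bearing chains stand apart from compound 1 by steps beyond the scatter. Nothing available here accounts for this difference between compound 1 and the hydroxy-bearing chains.

The compounds shown leave open whether the difference from compound 1 follows from the presence of the hydroxy group or from the loss of vinyl, a question that a plain propoxy chain on the same core could address. They also leave open how this position would respond to an amine or a carboxylic acid in place of the hydroxy, or to a longer hydroxy-bearing chain.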